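Benzyl change on compound 1 toward a nitrile analogue

A few compounds are considered here, and "the series" means these few. Any claim that something is new, unique, unknown or untested is made for them only; others in the source may bear on it.

Measured compounds:
compound 1 `COc1ccc(Cc2cnc(CCc3ccc(-c4ccccc4C(=O)O)cc3)[nH]2)cc1`: 513 nM
compound 2 `CCCCc1cnc(C(Cc2ccc(-c3ccccc3C(=O)O)cc2)C(C)C)[nH]1`: 2240 nM
compound 3 `O=C(O)c1ccccc1-c1ccc(CCc2ncc(Cc3ccccc3Cl)[nH]2)cc1`: 22 nM

In an in vitro functional assay on cells for agonist activity at Bombesin receptor subtype-3 (Mus musculus), read by luminescence and calcium flux (a lower number here means that less compound is needed, a higher number that more compound is needed for the effect), compound 1 gives 513 nM, the second highest of the three numbers. Going by the values given here, compound 2 stands furthest up with 2240 nM, beyond the scatter from compound 1, though compound 2 differs from compound 1 in more than one place and no single step links them. Compound 3 stands lowest with 22 nM, and the one-place step between them is a 23-fold lower number from compound 1 to compound 3 (1.37 log units; beyond the scatter).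

Compound 4 `N#Cc1ccccc1Cc1cnc(CCc2ccc(-c3ccccc3C(=O)O)cc2)[nH]1` has not yet been measured. Against compound 1 the change is 2-cyanophenyl in place of 4-methoxyphenyl on a saturated chain carbon bound to an aromatic carbon. Among the compounds with values here, the only measured step that bears on it is the one from compound 1 to compound 3, which also replaced the 4-methoxyphenyl with a substituted phenyl on the same saturated chain carbon and gave a large lowering. The group entering here is a 2-cyanophenyl rather than a 2-chlorophenyl, so the same size of step cannot be assumed, but a lowering beyond the scatter is the expectation in this assay, on the strength of a 23-fold lower number from compound 1 to compound 3 (1.37 log units; beyond the scatter). The expected step is a 5.7-fold lower number from compound 1 to compound 4 (0.76 log units; beyond the scatter). Compound 4 is estimated at 90 nM, with a range from 25 nM to 300 nM.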

Compound 4, half-maximal effective concentration: 642 nM
Compound 4: middle estimate off by 7.1-fold (0.85 log units), on the low side; measured number above the stated range.
By their numbers in this assay, from the lowest: compound 3; then compounds 1 and 4 (each within the scatter of the next); then compound 2.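

In this assay, replacing 4-methoxyphenyl with 2-cyanophenyl on a saturated chain carbon bound to an aromatic carbon gives a 1.3-fold higher number from compound 1 to compound 4 (0.10 log units; within the scatter) and so does not repeat the lowering seen with 2-chlorophenyl at the same place. With only cyano in place of chloro on an aromatic carbon, the result is a 29-fold higher number from compound 3 to compound 4 (1.47 log units; beyond the scatter) in this assay, which shows that the low number of compound 3 depends on the chloro group and does not follow from removing 4-methoxyphenyl or from merely having some group in its place. No available measurement accounts for this difference between chloro and cyano.

The compounds shown leave open whether the low number of compound 3 is specific to chloro or would also appear with 2-fluorophenyl, 2-bromophenyl or 2-methylphenyl at this place. They also leave open how an unsubstituted phenyl or a 4-chlorophenyl would stand against compound 3 and compound 1, and so whether the chloro group needs to be placed as it is in 2-chlorophenyl.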